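Removing the Methoxymethyl Group Again: Compound 4

This account rests on a few compounds, and the source may have more. Where it says the series, first, only, none or still open, it means among the compounds named here.

Measured so far:
compound 1, `CC/C=C\C/C=C\C/C=C\CCCCCCCc1cc(=O)c2c(O)cc(O)cc2o1`: 17500 nM
compound 2, `CC/C=C\C/C=C\C/C=C\CCCCCCCc1cc(=O)c2c(O)cc(OCOC)cc2o1`: 17500 nM
compound 3, `CCCCC/C=C\C/C=C\CCCCCCCc1cc(=O)c2c(O)c(C)c(OCOC)cc2o1`: a limit only, > 67200 nM

In a functional assay on MCF7 cells (Homo sapiens) for antiproliferative activity, read by MTT assay (on this read-out lower numbers stand for stronger inhibition and higher numbers for weaker inhibition), compound 2 gives 17500 nM and compound 1 gives 17500 nM. The change between them is hydrogen in place of methoxymethyl on an oxygen on an aromatic ring, and it made the step of no change at the digits printed from compound 2 to compound 1 (within the scatter). Compound 3 has no number in this assay, only a limit, > 67200 nM, which is the limit of > 67200 nM in this assay, at which 1 of the 3 values shown sits. How the core of compound 3 differs from that of compound 2 is not broken down here.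

Compound 4, `CCCCC/C=C\C/C=C\CCCCCCCc1cc(=O)c2c(O)c(C)c(O)cc2o1`, is not yet measured. It differs from compound 3 by hydrogen in place of methoxymethyl on an oxygen on an aromatic ring, and since the place of the change is worded exactly as for the pair of compound 2 and compound 1, this is the same change made a second time. The earlier step was within the scatter, and that is what the expectation for compound 4 rests on: the step that the limit leaves unreadable from compound 3 to compound 4 is expected to be small as well. Because compound 3 sits at > 67200 nM, compound 4 is expected to remain weak, near 90000 nM, between 30000 nM and 250000 nM.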

Compound 4, half-maximal inhibitory concentration: > 84100 nM
Compound 4: a limit, no number (the forecaster's own chance of this, stated with the estimate: 60%); the middle value lies beyond the limit too.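

In this assay compound 3 gives only a limit, > 67200 nM, and not a number. Compound 4 also gives only a limit, > 84100 nM, and no step can be read between these two compounds. The compounds shown leave open whether removing the methoxymethyl group changes activity in this pair, and how weak either compound really is.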